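The source may report more compounds than this note shows. Statements on the series, on what has been measured and on what is new or still open speak of the compounds shown alone.

Within the data shown here, in a functional assay on PANC-1 cells (Homo sapiens) for antiproliferative activity, read by sulforhodamine B assay, with a stated time of 48 h (on this read-out higher numbers stand for weaker inhibition of growth and lower numbers for stronger inhibition of growth), compound 1 (`Cc1cc2c(cc1C)C(Cl)=C(c1nnc(-c3ccccc3)o1)CCC2`) gives 4120 nM and compound 2 (`Cc1cc2c(cc1C)C(Cl)=C(c1nnc(-c3ccc(F)cc3)o1)CCC2`) gives 520 nM as the lower of the two numbers so far. Compound 3 (`Cc1cc2c(cc1C)C(Cl)=C(c1nnc(-c3cccc(Cl)c3)o1)CCC2`) has 3-chlorophenyl in place of 4-fluorophenyl (3-chlorophenyl in place of 4-fluorophenyl on an aromatic carbon). Among the measured compounds shown here, only one measured step bears on this (a 7.9-fold lower number from compound 1 to compound 2 (0.90 log units; beyond the scatter)) and it is modest, for fluoro in place of hydrogen on an aromatic carbon. For the measured compounds named here, no chlorine-bearing compound has been measured yet, so only a small step toward a higher number is expected in this assay, with a wide margin. The expected step is a 2.1-fold higher number from compound 2 to compound 3 (0.33 log units; beyond the scatter) as estimated here. Compound 3 is expected at 1100 nM (estimated range 300 nM to 3500 nM).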

Compound 3, concentration for 50% growth inhibition: 4570 nM
For compound 3 the middle estimate is 4.2-fold (0.62 log units) below the measured one, outside the stated range (above it).
By their numbers in this assay, from the lowest: compound 2; then compounds 1 and 3 (each within the scatter of the next).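

In this assay, the 3-chlorophenyl group gives a 1.1-fold higher number from compound 1 to compound 3 (0.05 log units; within the scatter) and so does not reproduce the gain seen with 4-fluorophenyl. The change to 3-chlorophenyl gives an 8.8-fold higher number from compound 2 to compound 3 (0.94 log units; beyond the scatter) as a loss of that gain, but it alters both the halogen and its ring position, and the compounds shown cannot separate the two. No available evidence bears on why this happens.

Open, on these data alone, is whether 4-chlorophenyl or 3-fluorophenyl would separate halogen from position. Also open, as far as these compounds go, is how an amine or a carboxylic acid on this phenyl ring would compare with the 4-fluorophenyl of compound 2.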